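The compounds below may be only part of what the source reports. "The series", "measured", "known", "first", "only" and "open" are said of these compounds alone.

Measured compounds in a functional assay on U-87MG ATCC cells for antiproliferative activity against U-87 MG (Homo sapiens), read by MTT assay, with a stated time of 48 h, tested at 50 uM; a higher number here means a weaker effect of the compound at the concentration tested, a lower number a stronger effect:

compound 1, `COc1ccc(-c2nc(C)c(C(=O)CSc3nc(N)c(C#N)c(-c4ccc(OC)cc4)n3)s2)cc1`, 13%
compound 2, `Cc1nc(-c2ccccc2)sc1C(=O)CSc1nc(-c2ccccc2)c(C#N)c(=O)[nH]1`, 77.5%
compound 3, `Cc1nc(-c2ccc(Cl)cc2)sc1C(=O)CSc1nc(-c2ccccc2)c(C#N)c(=O)[nH]1`, 41.6%

Compound 2 gives the highest number of the three, compound 3 being nearest and compound 1 furthest, both beyond the scatter. Compound 4, `COc1cccc(-c2nc(SCC(=O)c3sc(-c4ccccc4)nc3C)[nH]c(=O)c2C#N)c1`, is not yet measured. It differs from compound 2 by methoxy in place of hydrogen on an aromatic carbon.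

Within the data shown here, the only measured step that touches a single aromatic hydrogen is a number 35.9 percentage points lower from compound 2 to compound 3 (beyond the scatter), but that step concerns a different group on a different ring, and compound 1 differs from compound 2 in too many places to isolate a methoxy effect. So the expectation for compound 4 is a step of a number 17.5 percentage points lower from compound 2 to compound 4 (beyond the scatter), downward from compound 2 but with wide uncertainty. Compound 4 is therefore estimated at 60%, in the range 30% to 85%.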

Compound 4, a percentage reported as activity, at one concentration (the size of the read-out at that concentration, not a potency): 80.3%
Beside the measured number, compound 4's estimate is 20.3 percentage points below it; measured number inside the range.
By their numbers in this assay, from the lowest: compound 1; then compound 3; then compounds 2 and 4 (each within the scatter of the next).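

In this assay, the change from phenyl to 3-methoxyphenyl gives a number 2.8 percentage points higher from compound 2 to compound 4 (within the scatter), so methoxy at this place, meta to a large group, brings no shift beyond the scatter. By contrast, chloro in place of hydrogen on the other aromatic ring gives a number 35.9 percentage points lower from compound 2 to compound 3 (beyond the scatter), so the two rings cannot be treated as one position. No measurement at hand bears on the reason for this result.

Open, on these data alone, is whether an amine or a carboxylic acid at this same place would shift the number, and whether chloro would do so here.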